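The compounds below may be only part of what the source reports. "The series", "measured", "known", "first", "only" and "open" are said of these compounds alone.

Measured compounds:
compound 1 `CC(=O)Nc1cc(Nc2cc(NC3CC3)n3ncc(C#N)c3n2)ccc1N1CC[C@H](N(C)C)C1` – 2.5 uL/min
compound 2 `CC(=O)Nc1cc(Nc2cc(NC3CC3)n3ncc(C#N)c3n2)ccc1N1CCC[C@H](N)C1` – < 1 uL/min

In an ADME assay on cells (Hepatocyte, Rattus norvegicus) for metabolic stability (on this read-out higher numbers stand for fast clearance and lower numbers for slow clearance), compound 1 gives 2.5 uL/min. Compound 2 gives only < 1 uL/min, which is a limit of this assay and not a number, so compound 2 sits at the limit of < 1 uL/min in this assay, at which 1 of the 2 values shown sits, and its true value is open downward. Among the compounds with values here, the single measured step, an at least 2.5-fold lower number from compound 1 to compound 2 (0.39 log units; beyond the scatter), is the only guide available; it moved the number downward, but it swapped one amine for another as well as one ring for another, so it does not isolate either change.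

Compound 3 `CC(=O)Nc1cc(Nc2cc(NC3CC3)n3ncc(C#N)c3n2)ccc1N1CC[C@H](N)C1` differs from compound 2 by 3-aminopyrrolidin-1-yl in place of 3-aminopiperidin-1-yl on an aromatic carbon. Within the data shown here, with only this one step to draw on, and that step pointing toward slow clearance, the estimate for compound 3 is that it stays close to where compound 2 sits, with no step beyond the scatter expected in this assay, a number no lower from compound 2 to compound 3 (the limit leaves the size open). Compound 3 is expected to give about 1 uL/min, estimated between 0.4 uL/min and 2.5 uL/min.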

Compound 3, intrinsic clearance in a liver preparation (reported as CLH), per the amount of preparation that the assay uses: < 1 uL/min
Compound 3 was reported as a limit; the forecaster's own chance of this, stated with the estimate: 50%; the middle value lies on the limit itself.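

In this assay, compound 3 separates the two changes that were mixed in the earlier step. With the saturated ring kept, amino in place of dimethylamino gives an at least 2.5-fold lower number from compound 1 to compound 3 (0.39 log units; beyond the scatter), so the change of amine alone is enough to lower the number, whatever ring size does. The values of compound 2 and compound 3 are both limits of the assay and not numbers, so the step between them cannot be read and nothing can be said about the six-membered against the five-membered ring: the limit of < 1 uL/min in this assay, at which 2 of the 3 values shown sit.

As far as these compounds go, how far compound 2 and compound 3 lie beyond that limit stays open, and with it any effect of ring size on the primary amines. Also open, from the compounds shown here alone, is where a methylamino group on the same ring carbon would fall in this assay.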